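Dropping the chloro from a halogenated chromone dithiazole

The compounds below may be only part of what the source reports. "The series", "measured", "known", "first", "only" and "open" are said of these compounds alone.

Measured so far:
Compound 1, `O=c1c(C2N=C(c3ccccc3)SS2)coc2ccc(F)cc12`: 51%
Compound 2, `O=c1c(C2N=C(c3ccccc3)SS2)coc2cc(Cl)ccc12`: 31%

In a functional assay on HEp-2 cells (Homo sapiens) for inhibition, read by sulforhodamine B assay, with a stated time of 48 h, tested at 100 uM (on this read-out higher numbers stand for more inhibition of growth at the one concentration tested and lower numbers for less inhibition of growth), compound 1 gives 51%. Among the measured compounds shown here, compound 2 stands lowest of the two numbers; its nearest neighbour is compound 1, whose value lies higher by a gap said to be beyond the scatter, though no single-point step between the two is available, since they differ in more than one place. Compound 3, `O=c1c(C2N=C(c3ccccc3)SS2)coc2ccccc12`, has not yet been tested in this assay. It differs from compound 2 by hydrogen in place of chloro on an aromatic carbon. For the measured compounds named here, no comparable step between measured compounds is known, so the expectation rests on the two values alone. The step from compound 2 to compound 3 is expected to be small, at most a slight rise, and most likely within the scatter, giving a number 9 percentage points higher from compound 2 to compound 3 (within the scatter). Compound 3 is therefore estimated at 40%, with a range from 20% to 60%.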

Compound 3, percent growth inhibition at one concentration: 48%
Estimate against measurement, compound 3: 8 percentage points below; low and high end bracket the measured number.
By their numbers in this assay, from the lowest: compound 2; then compounds 3 and 1 (each within the scatter of the next).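

In this assay, hydrogen in place of chloro on this aromatic carbon, meta to a fused ring and para to a fused ring, gives a number 17 percentage points higher from compound 2 to compound 3 (beyond the scatter) and so shows that the chloro at this place goes with less inhibition of growth. Hydrogen in place of fluoro on an aromatic carbon, at a different place on the shared core, gives a number 3 percentage points lower from compound 1 to compound 3 (within the scatter) and so leaves no readable difference between those two compounds. Nothing available explains why the chloro step exceeds the scatter in this way.

On these data alone, whether an amine, a methoxy group or a carboxylic acid on the carbon that carries the chloro would read closer to compound 2 or to compound 3 stays open. As far as these compounds go, it is also open whether a chloro at the place of the fluoro in compound 1 would give a similar step.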